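Working notes: amino substituent size in a herbicidal series

The source may hold more compounds than are shown below. What is called first, only, known or untested is meant among the compounds shown, and "the series" means these compounds.

Measured compounds:
compound 1 `CCNc1nc(Cl)nc(N[C@H](C)c2ccccc2)n1` — 2690 nM
compound 2 `CC[C@@H](C)Nc1nc(Cl)nc(N[C@@H](C)c2ccccc2)n1` — 7410 nM

Both were tested in an ADME assay on the whole organism for inhibition, with Echinochloa crus-galli var. formosensis as the target, with a stated time of 4 days; a higher number here means a weaker inhibitor, a lower number a stronger inhibitor. Compound 2 stands at the highest number of the two; its nearest neighbour is compound 1, whose value lies below it by a gap beyond the scatter. Compound 3 `CCC(CC)Nc1nc(Cl)nc(N[C@@H](C)c2ccccc2)n1` is not yet measured. It differs from compound 2 in one place: pentan-3-yl in place of sec-butyl on a nitrogen on an aromatic ring. Going by the values given here, no single-change step between measured compounds exists, so the expectation rests on the two values alone. For compound 3 a small step of a 1.3-fold higher number from compound 2 to compound 3 (0.11 log units; within the scatter) toward a weaker inhibitor is expected, possibly none beyond the scatter. Compound 3 is therefore estimated at 9500 nM, within 3500 nM to 26000 nM.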

Compound 3, half-maximal inhibitory concentration: 23400 nM
The estimate for compound 3 lay 2.5-fold (0.39 log units) below the measured number; the measured number falls inside the stated range.
By their numbers in this assay, from the lowest: compound 1; then compound 2; then compound 3.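

In this assay, going by these compounds alone, the (sec-butyl)amino to (pentan-3-yl)amino change gives a 3.2-fold higher number from compound 2 to compound 3 (0.50 log units; beyond the scatter), the first single-change step, and it shows that this nitrogen substituent is not indifferent to a modest change in the alkyl group. The change also removes the defined stereocentre of sec-butyl, so the step alone cannot separate the added carbon from the lost stereocentre. Nothing at hand explains the step.

Open, from the compounds shown here alone, is whether isopropyl or cyclopentyl on the same nitrogen would continue this direction or reverse it.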